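Urotensin-2 antagonists: amide to aminopyrazine on the side chain

The compounds below may be only part of what the source reports. "The series", "measured", "known", "first", "only" and "open" are said of these compounds alone.

Measured compounds:
compound 1 `CCN1CCN(c2cccc3c2CN([C@H](CCCNC(=O)c2cccs2)c2ccc(OC)c(OC)c2)C3=O)CC1` — 140 nM
compound 2 `COc1ccc([C@@H](CCCN(C)S(=O)(=O)c2cccs2)N2Cc3c(cccc3N3CCN(C4CCC4)CC3)C2=O)cc1OC` — 510 nM
compound 3 `COc1ccc([C@@H](CCCN(C)S(=O)(=O)c2cccs2)N2Cc3c(cccc3N3CCNCC3)C2=O)cc1OC` — 410 nM

In a functional assay on RMS13 cells for antagonist activity at Urotensin-2 receptor (Homo sapiens), read by FLIPR and calcium flux, with a stated time of 1 h (a higher number here means a weaker inhibitor, a lower number a stronger inhibitor), compound 1 gives the lowest of the three numbers; compound 3 is nearer to it and compound 2 further, both gaps beyond the scatter. Within the data shown here, the only single-place step among the measured compounds, a 1.2-fold lower number from compound 2 to compound 3 (0.09 log units; within the scatter), concerns the amine nitrogen in the piperazine ring and lies within the scatter.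

Compound 4 `CCN1CCN(c2cccc3c2CN([C@H](CCCNc2cncc(OC)n2)c2ccc(OC)c(OC)c2)C3=O)CC1` differs from compound 1 as follows: 6-methoxypyrazin-2-yl in place of (thiophen-2-yl)carbonyl on an amine nitrogen. Among the measured compounds shown here, no measured step bears on this position; the side-chain variants in compound 2 and compound 3 carry a different group there and also differ elsewhere, so their values only show that compound 2 and compound 3 sit higher than compound 1, with gaps beyond the scatter. The expected step is therefore uncertain and is set as a 1.9-fold higher number from compound 1 to compound 4 (0.27 log units; within the scatter), a mild loss against compound 1 with a wide band. Compound 4 is estimated at 260 nM, between 70 nM and 1000 nM.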

Compound 4, half-maximal inhibitory concentration: 62 nM
Compound 4: middle estimate off by 4.2-fold (0.62 log units), on the high side; measured number below the stated range.
By their numbers in this assay, from the lowest: compound 4; then compound 1; then compounds 3 and 2 (each within the scatter of the next).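

In this assay, replacing (thiophen-2-yl)carbonyl with 6-methoxypyrazin-2-yl on the amine nitrogen gives a 2.3-fold lower number from compound 1 to compound 4 (0.35 log units; beyond the scatter) as a modest gain beyond the scatter. In this pair, neither the carbonyl nor the five-membered aromatic ring is required at this position, and a six-membered aromatic ring with two hetero atoms is accepted there with a lower number. Nothing measured here explains the step.

From the compounds shown here alone, this single pair does not separate the contribution of the pyrazine ring from that of its methoxy group, so unsubstituted pyrazin-2-yl or a chloro or ethoxy group in place of methoxy remains open. Also open, going by these compounds, are a methyl group on the linking amine nitrogen, a longer chain, and whether the step carries over when the piperazine nitrogen bears hydrogen or cyclobutyl instead of ethyl.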